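Urea to amide change on the pyrazole series

The source may hold more compounds than are shown below. What is called first, only, known or untested is meant among the compounds shown, and "the series" means these compounds.

Compound 1 `O=C(Nc1cccc(-n2cc(-c3ccncc3)c(-c3cc(O)cc(Cl)c3)n2)c1)Nc1ccc(Cl)c(C(F)(F)F)c1` gives 109% in a functional assay on OVCAR-5 cells (Homo sapiens) for inhibition, read by sulforhodamine B assay, with a stated time of 48 h, tested at 1 uM (a higher number here means a weaker effect of the compound at the concentration tested, a lower number a stronger effect), and compound 2 `COc1cc(Cl)cc(-c2nn(-c3cccc(NC(=O)Nc4ccc(Cl)c(C(F)(F)F)c4)c3)cc2-c2ccncc2)c1` gives 81%, the lower of the two numbers, with the step of a number 28 percentage points lower from compound 1 to compound 2 (beyond the scatter). Compound 3 `COc1cc(Cl)cc(-c2nn(-c3cccc(NC(=O)c4cccc(C(F)(F)F)c4)c3)cc2-c2ccncc2)c1` differs from compound 2 by 3-(trifluoromethyl)phenyl in place of (4-chloro-3-(trifluoromethyl)phenyl)amino on a carbonyl carbon. Among the compounds with values here, no measured step bears on this change; the only step seen concerns the methyl on the oxygen, which stays. With the urea link in compound 2 replaced by an amide, the expected step is a number 9 percentage points higher from compound 2 to compound 3 (within the scatter), within or near the scatter and slightly toward weaker effect. Compound 3 is therefore estimated at 90%, with a range from 65% to 115%.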

Compound 3, a percentage reported as activity, at one concentration (the size of the read-out at that concentration, not a potency): 96%
For compound 3 the middle estimate is 6 percentage points below the measured one, and the stated range covers the measured number.
By their numbers in this assay, from the lowest: compound 2; then compound 3; then compound 1.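

In this assay the carbonyl carbon now has a reading of its own, a number 15 percentage points higher from compound 2 to compound 3 (beyond the scatter), so this site moves the number as well as the methyl on the oxygen. The change removes the amino nitrogen and the chlorine together, and the step cannot divide its size between the two. Nothing available gives a reason for the step.

Still open, as far as these compounds go, is how a 4-chloro-3-(trifluoromethyl)phenyl placed directly on the carbonyl carbon would read, which would separate those two losses. From the compounds shown here alone, a methylene in place of the amino nitrogen is also open.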